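The compounds below may be only part of what the source reports. "The series", "measured", "known", "first", "only" and "open" are said of these compounds alone.

For the measured compounds named here, compound 2 `CCOc1cc(NC(=O)NCc2cc(C)c(-c3cn(C)nc3C(F)(F)F)cn2)cc(Cl)n1` gives the higher of the two numbers so far measured in a functional assay on CHO cells for antagonist activity at sphingosine 1-phosphate receptor 2 (Homo sapiens), read by scintillation counting and GTPgammaS binding, with a stated time of 4 h, in the presence of a further agent that is not named here; on this read-out lower numbers stand for stronger inhibition and higher numbers for weaker inhibition: compound 2 shows 22 nM, whereas compound 1 `CCOc1cc(NC(=O)NCc2cc(C)c(-c3cn(C)nc3C)cn2)cc(Cl)n1` shows 0.32 nM. Going by the values given here, the only measured step, a 69-fold higher number from compound 1 to compound 2 (1.84 log units; beyond the scatter), is large, so what sits on this aromatic carbon matters greatly in this assay. Compound 3 `CCOc1cc(NC(=O)NCc2cc(C)c(N3CC(C)OC(C)C3)cn2)cc(Cl)n1` carries a different change on the same aromatic carbon: 2,6-dimethylmorpholin-4-yl in place of 1-methyl-3-(trifluoromethyl)-1H-pyrazol-4-yl on an aromatic carbon. Among the compounds with values here, no measured pair shows a non-aromatic ring entering there, so the single large step from compound 1 to compound 2 gives the scale of what this carbon can do but not the direction for compound 3. A change of moderate size in this assay is therefore expected, with wide uncertainty on either side. Compound 3 is expected to give about 8 nM, within 1 nM to 80 nM. That estimate corresponds to an expected step of a 2.8-fold lower number from compound 2 to compound 3 (0.44 log units; beyond the scatter).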

Compound 3, half-maximal inhibitory concentration: 105 nM
Compound 3: middle estimate off by 13-fold (1.12 log units), on the low side, outside the stated range (above it).
By their numbers in this assay, from the lowest: compound 1; then compound 2; then compound 3.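

In this assay, the first non-aromatic ring on this aromatic carbon gives the highest number of the three compounds: 2,6-dimethylmorpholin-4-yl brings a 4.8-fold higher number from compound 2 to compound 3 (0.68 log units; beyond the scatter), a modest step, and a 330-fold higher number from compound 1 to compound 3 (2.52 log units; beyond the scatter), a large one. Both changes away from 1,3-dimethyl-1H-pyrazol-4-yl at this carbon therefore raise the number, and the morpholine raises it further than the trifluoromethyl pyrazole does. Nothing available explains why this ring fares worse than either pyrazole.

The three compounds cannot separate the loss of the five-membered aromatic ring from the effect of the two methyl groups on the morpholine, since these changes arrive together in compound 3. A plain morpholin-4-yl without those methyl groups, or a phenyl ring on the same carbon, would be needed to tell them apart.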